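Bis(trifluoromethyl)benzenesulfonamide amines: a benzodioxinylmethyl variant

This account rests on a few compounds, and the source may have more. Where it says the series, first, only, none or still open, it means among the compounds named here.

Measured compounds:
compound 1 `O=S(=O)(NCCCNCc1ccc(Cl)cc1)c1cc(C(F)(F)F)cc(C(F)(F)F)c1` — 1800 nM
compound 2 `O=S(=O)(NCCNCc1ccc(-c2ccccc2)cc1)c1cc(C(F)(F)F)cc(C(F)(F)F)c1` — 2600 nM

In a functional assay on A2780 cells (Homo sapiens) for inhibition, read by MTT assay, with a stated time of 72 h (a higher number here means a weaker inhibitor of growth, a lower number a stronger inhibitor of growth), compound 1 gives 1800 nM, and compound 2 gives 2600 nM. The two numbers lie within the usual scatter of each other, so neither compound is distinguished from the other on the data shown; compound 1 simply stands as one of two closely grouped measurements.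

Compound 3 `O=S(=O)(NCCCNCC1COc2ccccc2O1)c1cc(C(F)(F)F)cc(C(F)(F)F)c1` has not been measured. It differs from compound 1 in one place: 2,3-dihydro-1,4-benzodioxin-2-yl in place of 4-chlorophenyl on a saturated chain carbon bound to an amine nitrogen. Going by the values given here, no measured pair isolates this kind of change, and the only comparison at hand, compound 1 against compound 2, shows that a different aryl group on the amine side leaves the number within the scatter. The step from compound 1 to compound 3 is therefore expected to be small, a 1.4-fold higher number from compound 1 to compound 3 (0.14 log units; within the scatter), with no clear direction beyond the scatter. Compound 3 is estimated at 2500 nM, in the range 1000 nM to 6500 nM.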

Compound 3, concentration for 50% growth inhibition: 1500 nM
Compound 3: middle estimate off by 1.7-fold (0.22 log units), on the high side; the range from low to high includes it.
By their numbers in this assay, from the lowest: compounds 3, 1 and 2 (each within the scatter of the next).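

Going by these compounds alone, this is the first comparison that isolates one change: in this assay, 2,3-dihydro-1,4-benzodioxin-2-yl in place of 4-chlorophenyl gives a 1.2-fold lower number from compound 1 to compound 3 (0.08 log units; within the scatter), with the rest of the structure held constant. On a saturated chain carbon bound to an amine nitrogen, the single aromatic ring can thus give way to a group with one non-aromatic and one aromatic ring and 2 hydrogen-bond acceptors, and the number stays within the scatter. Nothing available explains why the number holds across this change.

Still open, from the compounds shown here alone, is whether a pyridine ring or a carboxylic acid at this place would move the number beyond the scatter. Compound 1 and compound 2 differ in more than one place, so they cannot show what a longer chain would do.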